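The compounds below may be only part of what the source reports. "The series", "measured", "known", "first", "only" and "open" are said of these compounds alone.

Of the compounds shown here, two from this series have been tested in a functional assay on CHO cells for antagonist activity at sphingosine 1-phosphate receptor 2 (Homo sapiens), read by scintillation counting and GTPgammaS binding, with a stated time of 4 h, in the presence of a further agent that is not named here; on this read-out lower numbers stand for stronger inhibition and higher numbers for weaker inhibition. Compound 1 `CCOc1cc(NC(=O)NCc2cc(C)c(-c3cn(C)nc3C(F)(F)F)nn2)cc(C)n1` gives 242 nM in this assay. Compound 2 `CCOc1nc(C)cc(NC(=O)NCc2cc(C)c(-c3cn(C)nc3C(F)(F)F)nn2)c1Cl` differs from compound 1 only by a chloro group on an aromatic carbon in place of hydrogen. In this assay compound 2 gives 26 nM. Within the data shown here, of the two numbers measured so far, that of compound 2 is the lower, and compound 1 is its only neighbour for comparison.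

Compound 3 `CCOc1nc(C)cc(NC(=O)NCc2cc(C)c(-c3cn(C)nc3C(F)(F)F)nn2)c1C#N` is the next step: cyano in place of chloro on an aromatic carbon. Among the measured compounds shown here, the single measured step that touches this carbon is the one in which chloro replaced hydrogen, giving a 9.3-fold lower number from compound 1 to compound 2 (0.97 log units; beyond the scatter), which shows that a substituent at this position can move the number well beyond the scatter. For the measured compounds named here, no measured pair shows cyano in place of chloro, so the size of the coming step is uncertain. The expectation for compound 3 is a number near that of compound 2, with the step of a 1.2-fold higher number from compound 2 to compound 3 (0.06 log units; within the scatter) expected to fall within the scatter. The estimate for compound 3 in this assay is 30 nM, with a range from 8 nM to 120 nM.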

Compound 3, half-maximal inhibitory concentration: > 20000 nM
Compound 3 was reported as a limit (the forecaster's own chance of this, stated with the estimate: 3%); middle value at least 660-fold (2.82 log units) from the limit.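

For compound 3, the reading in this assay is a limit and not a number: the limit of > 20000 nM in this assay, at which 1 of the 3 values shown sits.

Even so, replacing chloro with cyano on this aromatic carbon gives an at least 760-fold higher number from compound 2 to compound 3 (2.88 log units; beyond the scatter), and measured against the hydrogen of the first compound in the series, the same group gives an at least 82-fold higher number from compound 1 to compound 3 (1.91 log units; beyond the scatter). The earlier pair showed only one direction, with chloro giving a 9.3-fold lower number from compound 1 to compound 2 (0.97 log units; beyond the scatter), whereas these steps show that a group on this carbon can also push the number far the other way, so the outcome depends on which group sits there and not simply on whether the hydrogen has been replaced.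

With only hydrogen, chloro and cyano shown on this carbon, it remains open whether a bromo group, a methoxy group or an amine would behave like chloro or like cyano. These compounds also cannot tell whether the change in the number goes with the hydrogen-bond acceptor that cyano brings, with its triple bond, or with something else about the group.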